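The compounds below may be only part of what the source reports. "The series", "measured", "known", "first", "only" and "open" are said of these compounds alone.

Values in an assay on membranes from Sf9 cells for displacement of a labelled ligand from histamine H2 receptor (Homo sapiens), read by scintillation counting, with a stated time of 60 min (on this read-out higher numbers stand for weaker inhibition and lower numbers for stronger inhibition), for the measured compounds:

compound 1, `Cc1nc(N)sc1CCCN/C(N)=N/C(=O)NC1CCCCC1`: 170 nM
compound 2, `CCCCCCNC(=O)/N=C(\N)NC1CCc2nc(N)sc2C1`: 1120 nM
compound 3, `Cc1ccc(C(C)NC(=O)/N=C(\N)NCCCc2sc(N)nc2C)cc1`: 30.9 nM

Compound 3 gives the lowest number of the three. Compound 1 comes nearest to it, and compound 2 lies furthest from it; both gaps are beyond the scatter. No two of these compounds differ in one place, so no measured step exists in this set.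

Compound 4, `Cc1nc(N)sc1CCCN/C(N)=N/C(=O)NC(C)c1ccc(F)cc1`, is not yet measured. It differs from compound 3 by fluoro in place of methyl on an aromatic carbon. Nothing measured here bears on this change, so the expectation rests on compound 3 alone. The step from compound 3 to compound 4 is expected to be small, a 1.5-fold higher number from compound 3 to compound 4 (0.16 log units; within the scatter), not clearly beyond the scatter in either direction. Compound 4 is therefore estimated at 45 nM, within a range of 15 nM to 140 nM.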

Compound 4, inhibition constant: 31.6 nM
Compound 4: the middle estimate sits 1.4-fold (0.15 log units) above what was measured, within the range that was stated.
By their numbers in this assay, from the lowest: compounds 3 and 4 (each within the scatter of the next); then compound 1; then compound 2.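

In this assay, going by these compounds alone, fluoro in place of methyl on the aromatic carbon gives a 1.0-fold higher number from compound 3 to compound 4 (0.01 log units; within the scatter), the only single-place step measured. At this position, para to a large group, the exchange of 4-methylphenyl for 4-fluorophenyl therefore leaves no measurable mark on the read-out. No supporting data bear on why this is so.

Going by these compounds, whether this tolerance extends to other groups at this position, such as chloro, methoxy, an amine or a carboxylic acid, stays open. Compound 1 and compound 2 have no single-place partner, so the contributions of their cyclohexyl and hexyl groups remain unread.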